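This account rests on a few compounds, and the source may have more. Where it says the series, first, only, none or still open, it means among the compounds named here.

The three measured compounds share one core. Compound 1 `Nc1nccn2cc(-c3ccccc3)nc12` gives 30% in an assay on cells for displacement of a labelled ligand from adenosine receptor A1 (Homo sapiens), read by scintillation counting, with a stated time of 120 min, tested at 1 uM; a higher number here means more inhibition at the concentration tested (going by the name of the read-out), a lower number less inhibition. Compound 2 `COc1cccc(-c2cn3cc(-c4ccccc4)nc3c(N)n2)c1` gives 37% in this assay, and compound 3 `Nc1nc(-c2ccc(Cl)cc2)cn2cc(-c3ccccc3)nc12` gives 3%. Compound 2 shows the highest of the three numbers, yet the step of a number 7 percentage points higher from compound 1 to compound 2 (within the scatter) lies within the scatter, so the two cannot be ranked against each other; the step of a number 34 percentage points lower from compound 2 to compound 3 (beyond the scatter) is beyond the scatter and large, and a number 27 percentage points lower from compound 1 to compound 3 (beyond the scatter) is likewise beyond it.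

Compound 4 `Nc1nc(-c2cccc(C(=O)O)c2)cn2cc(-c3ccccc3)nc12` arises from compound 2 by the change (carboxy in place of methoxy on an aromatic carbon). Among the measured compounds shown here, no measured step exchanges a methoxy for a carboxy anywhere in this set. The steps that touch the same aromatic carbon, a number 27 percentage points lower from compound 1 to compound 3 (beyond the scatter) and a number 34 percentage points lower from compound 2 to compound 3 (beyond the scatter), both run downward beyond the scatter, whereas a number 7 percentage points higher from compound 1 to compound 2 (within the scatter) stays within it; together they show that the group on this carbon can shift the read-out by a large amount, but they give no direction for a carboxy. The expectation is therefore a step of uncertain sign, most likely modest, with a wide range. Compound 4 is estimated at 25%, between 5% and 55%, meaning an expected step of a number 12 percentage points lower from compound 2 to compound 4 (beyond the scatter).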

Compound 4, a percentage reported as inhibition, at one concentration (the size of the read-out at that concentration, not a potency): 7%
Beside the measured number, compound 4's estimate is 18 percentage points above it; the range from low to high includes it.
By their numbers in this assay, from the lowest: compounds 3 and 4 (each within the scatter of the next); then compounds 1 and 2 (each within the scatter of the next).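

In this assay, the step of a number 30 percentage points lower from compound 2 to compound 4 (beyond the scatter) shows that the read-out at this position does not depend only on having a phenyl ring there: exchanging a single group on that ring, with the ring itself kept, is enough to carry the number beyond the scatter, whereas the earlier drop to compound 3 came with a different substitution pattern on the ring as well as a different group. Compound 4 at 7% and compound 3 at 3% lie within the scatter of each other, so two quite different substituted phenyl rings give numbers that cannot be told apart, and among the three compounds with a phenyl ring at this carbon, only compound 2 stays within the scatter of compound 1. Nothing in the data given explains why the carboxy gives this result.

Going by these compounds, it remains open whether a hydroxy, an amine or a methyl ester on the same carbon would read like the methoxy of compound 2 or like the carboxy of compound 4. Each number comes from one concentration. The compounds shown therefore give no potency for any of these groups.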